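The source may hold more compounds than are shown below. What is called first, only, known or untested is meant among the compounds shown, and "the series" means these compounds.

Working notes on the series.

Compound 1 `Cc1ccc(C(/C=C/c2ccc(Cl)cc2)=N/O)cc1` and compound 2 `Cc1ccc(C(/C=C/c2ccc(Br)cc2)=N/O)cc1` share one core and differ only in the halogen on the aromatic carbon. In a functional assay (Mus musculus, strain Balb/c) for inhibition, read by ELISA, with a stated time of 72 h (a higher number here means a weaker inhibitor, a lower number a stronger inhibitor), compound 1 gives 11600 nM, and in this assay compound 2 gives 11600 nM. Going by the values given here, the single measured step, no change at the digits printed from compound 1 to compound 2 (within the scatter), shows that exchanging one halogen for another at this position leaves the read-out where it was. Compound 2 therefore stands level with compound 1 on the numbers shown, with no step between them beyond the scatter.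

Compound 3 `Cc1ccc(C(/C=C/c2ccc(F)cc2)=N/O)cc1` is the next member and is not yet measured. Relative to compound 2 the change is fluoro in place of bromo on an aromatic carbon. Among the compounds with values here, the only step that bears on it is the one from compound 1 to compound 2, which was flat, so a further halogen swap at the same aromatic carbon is expected to give no step beyond the scatter in this assay, in either direction. The expected step is a 1.1-fold higher number from compound 2 to compound 3 (0.05 log units; within the scatter). Compound 3 is accordingly estimated at 13000 nM in this assay, with a range from 6000 nM to 30000 nM.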

Compound 3, half-maximal inhibitory concentration: 11300 nM
Estimate against measurement, compound 3: 1.2-fold (0.06 log units) above, within the range that was stated.
By their numbers in this assay, from the lowest: compounds 3, 1 and 2 (each within the scatter of the next).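

In this assay the exchange of fluoro for bromo on the aromatic carbon gives a 1.0-fold lower number from compound 2 to compound 3 (0.01 log units; within the scatter) and the exchange of fluoro for chloro gives a 1.0-fold lower number from compound 1 to compound 3 (0.01 log units; within the scatter) at the same place. The earlier compounds shown here covered only bromo and chloro; with fluoro added, all three halogens on this aromatic carbon, para to a large group, are joined by steps within the scatter, and the read-out does not separate them in any pairing, with no compound among the three going against this. Nothing shown here accounts for this flat read-out.

What the compounds shown leave open is whether this carbon accepts anything other than a halogen, since an amine, a carboxylic acid or a methoxy group in the same place could either stay level with the three halogen compounds or move the read-out well beyond the scatter. Also open, from the compounds shown here alone, is whether the flat halogen series would hold if the methyl group on the other aromatic ring gave way to a longer chain, because the shared core stays fixed across compound 1, compound 2 and compound 3.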